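The source may report more compounds than this note shows. Statements on the series, on what has been measured and on what is new or still open speak of the compounds shown alone.

Measured so far in an assay on isolated protein for inhibition of proto-oncogene tyrosine-protein kinase receptor Ret (Homo sapiens), read by 33P incorporation, with stated times of 15 min and 40 min; a higher number here means a weaker inhibitor, a lower number a stronger inhibitor:
- compound 1 `O=C(Nc1ccc(Cl)cc1)Nc1ccc(Nc2ncnc3c2OCCN3)cc1`: 3070 nM
- compound 2 `COc1cccc(NC(=O)Nc2ccc(Nc3ncnc4c3OCCN4)cc2)c1`: 6810 nM
- compound 3 `Cc1cc(C)cc(NC(=O)Nc2ccc(Nc3ncnc4c3OCCN4)cc2)c1`: 1070 nM

All three share one core and differ only in the group on an amide-type nitrogen whose other neighbour is the carbonyl carbon. Compound 3 holds the lowest of the three numbers in this assay. Its nearest neighbour is compound 1, a 2.9-fold lower number from compound 1 to compound 3 (0.46 log units; beyond the scatter); the furthest is compound 2, a 6.4-fold lower number from compound 2 to compound 3 (0.80 log units; beyond the scatter). The remaining step, a 2.2-fold higher number from compound 1 to compound 2 (0.35 log units; beyond the scatter), is of the same modest size.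

Compound 4 `O=C(Nc1ccc(Nc2ncnc3c2OCCN3)cc1)Nc1cccc2ccccc12` is not yet measured. The change from compound 3 is naphthalen-1-yl in place of 3,5-dimethylphenyl on an amide-type nitrogen. For the measured compounds named here, no measured step exchanges a one-ring group for a two-ring group at this position, so the three steps among compounds 1, 2 and 3 bear on it only as a gauge of how much the group on this nitrogen moves the number: each is modest, each beyond the scatter, in both directions. A modest step is therefore expected in this assay, with the direction uncertain and a slight lean toward a higher number. The estimate for compound 4 is 1500 nM, with a range of 400 nM to 6000 nM. That estimate corresponds to an expected step of a 1.4-fold higher number from compound 3 to compound 4 (0.15 log units; within the scatter).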

Compound 4, half-maximal inhibitory concentration: > 10000 nM
Compound 4 was reported as a limit; the forecaster's own chance of this, stated with the estimate: 5%; middle value at least 6.6-fold (0.82 log units) away from the limit.
By their numbers in this assay, from the lowest: compound 3; then compound 1; then compound 2. At a limit, above all of these: compound 4.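

In this assay compound 4 is reported only as a limit: the limit of > 10000 nM in this assay, at which 1 of the 4 values shown sits.

Among the one-ring groups on this nitrogen, every step was modest, whereas the two-ring naphthalen-1-yl gives an at least 9.3-fold higher number from compound 3 to compound 4 (0.97 log units; beyond the scatter) and an at least 3.2-fold higher number from compound 1 to compound 4 (0.51 log units; beyond the scatter), so the first of these floors already exceeds the largest step among compounds 1, 2 and 3. This position therefore does not accept every aromatic group equally, and a single exchange here can cost more than the one-ring series suggested. The comparison with the weakest one-ring compound is less informative, with an at least 1.4-fold higher number from compound 2 to compound 4 (0.16 log units; that floor lies within the scatter), so compound 4 is not clearly separated from compound 2.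

As far as these compounds go, how far compound 4 lies past its limit remains open. Also open, from the compounds shown here alone, is whether naphthalen-2-yl, or a phenyl ring carrying an amine or a carboxylic acid, would fare any differently at this nitrogen.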